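Swapping the thiophene for an ethynyl group on the shared core

A few compounds are considered here, and "the series" means these few. Any claim that something is new, unique, unknown or untested is made for them only; others in the source may bear on it.

Measured compounds in a functional assay on HCT-116 cells (Homo sapiens), read by MTT assay, with a stated time of 72 h; on this read-out lower numbers stand for stronger inhibition and higher numbers for weaker inhibition:
- compound 1 `COc1ncnc2c1c(-c1ccsc1)cn2[C@@H]1O[C@H](CO)[C@@H](O)[C@H]1O`: 140 nM
- compound 2 `COc1nc(N)nc2c1c(-c1ccsc1)cn2[C@@H]1O[C@H](CO)[C@@H](O)[C@H]1O`: compound 2 gives only a limit of the assay, > 20000 nM
- compound 3 `Cc1ncnc2c1c(-c1ccsc1)cn2[C@@H]1O[C@H](CO)[C@@H](O)[C@H]1O`: 1430 nM

Compound 1 gives the lowest number of the two numbers recorded; compound 3 sits nearest, and the step of a 10-fold higher number from compound 1 to compound 3 (1.01 log units; beyond the scatter) is a large one. The step of an at least 140-fold higher number from compound 1 to compound 2 (2.15 log units; beyond the scatter) is larger still. Compound 4 `C#Cc1cn([C@@H]2O[C@H](CO)[C@@H](O)[C@H]2O)c2ncnc(OC)c12` has not yet been measured. It differs from compound 1 in this way: ethynyl in place of thiophen-3-yl on an aromatic carbon. Going by these compounds, neither measured step touches the group that changes here; both alter the six-membered ring instead, so they give no direct guide, and the size and direction of the change remain open. A modest weakening is expected for compound 4, at an estimated 400 nM, within 80 nM to 2500 nM, which would mean an expected step of a 2.9-fold higher number from compound 1 to compound 4 (0.46 log units; beyond the scatter).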

Compound 4, half-maximal inhibitory concentration: 5140 nM
Beside the measured number, compound 4's estimate is 13-fold (1.11 log units) below it, and the stated range ends below it.
By their numbers in this assay, from the lowest: compound 1; then compound 3; then compound 4. At a limit, above all of these: compound 2.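

In this assay, the group on this aromatic carbon of the five-membered ring clearly matters: ethynyl in place of thiophen-3-yl gives a 37-fold higher number from compound 1 to compound 4 (1.56 log units; beyond the scatter). For the compounds shown here, the earlier steps changed only the six-membered ring, so this is the first sign that the number also depends on this position. Only compound 2 stands at a limit rather than a number: the limit of > 20000 nM in this assay, at which 1 of the 4 values shown sits.

Going by these compounds, how a phenyl ring, a furan ring or an aminomethyl group would fare on this carbon remains open. Also open, on these data alone, is whether ethynyl would give a similar step alongside the methyl or amino groups of compound 3 and compound 2.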